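A bromo swap on a barely active compound

The source may report more compounds than this note shows. Statements on the series, on what has been measured and on what is new or still open speak of the compounds shown alone.

- compound 1 `COc1cc2ncnc(Nc3ccc(CS(=O)(=O)/C=C/c4ccc(Cl)cc4Cl)cc3)c2cc1OC`: 24000 nM
- compound 2 `COc1cc2ncnc(Nc3ccc(CS(=O)(=O)/C=C/c4ccc(F)cc4)cc3)c2cc1OC`: > 100000 nM

Both compounds were tested in a functional assay on NCI/ADR-RES cells (Homo sapiens) for inhibition; on this read-out lower numbers stand for stronger inhibition of growth and higher numbers for weaker inhibition of growth. Compound 2 stands at the limit of > 100000 nM in this assay, at which 1 of the 2 values shown sits. That figure is a limit of the assay and not a number, so compound 2 has no exact position yet.

Compound 3 `COc1cc2ncnc(Nc3ccc(CS(=O)(=O)/C=C/c4ccc(Br)cc4)cc3)c2cc1OC` keeps everything in compound 2 except one group: bromo in place of fluoro on an aromatic carbon. In short, 4-fluorophenyl becomes 4-bromophenyl.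

Within the data shown here, only one measured step bears on this change: an at least 4.1-fold higher number from compound 1 to compound 2 (0.61 log units; beyond the scatter). Among the measured compounds shown here, it alters the halogens on the same aromatic ring, but it is a different swap, and no measured compound carries bromo. It does show that the halogens here can move the read-out beyond the scatter. A modest move toward a lower number in this assay is expected for compound 3. Compound 1, which carries no fluoro on this ring, gives 24000 nM. Compound 3 may still end up at the limit.

The expected change is an at least 2.0-fold lower number from compound 2 to compound 3 (0.30 log units; that floor lies within the scatter). For compound 3 the estimated value is 50000 nM, with an expected range of 20000 nM to 100000 nM.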

Compound 3, concentration for 50% growth inhibition: 72000 nM
The estimate for compound 3 lay 1.4-fold (0.16 log units) below the measured number; the measured number falls inside the stated range.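

The swap of fluoro for bromo gives an at least 1.3-fold lower number from compound 2 to compound 3 (0.14 log units; that floor lies within the scatter) in this assay, so no real gain from bromo is shown, even though compound 3 is the only compound here with a single halogen on this ring that has an exact number. Compound 2 is held only by a limit of the assay and not a number: the limit of > 100000 nM in this assay, at which 1 of the 3 values shown sits. The clearer comparison is with the 2,4-dichlorophenyl ring, which gives a 3.0-fold higher number from compound 1 to compound 3 (0.48 log units; beyond the scatter), so among these compounds a single bromo does not match the two chloro groups of compound 1, and all three remain weak on this read-out.

The compounds shown cannot separate the number of halogens on this ring from the kind of halogen or from where each halogen sits, as compound 1 and compound 3 differ in all of these at once. As far as these compounds go, whether an amine or a carboxylic acid in place of the halogen on this ring would bring the number down much further also stays open.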